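Swapping the aryl group on the ring nitrogen: a prediction

The compounds below may be only part of what the source reports. "The series", "measured", "known", "first", "only" and "open" are said of these compounds alone.

Of the compounds shown here, three sharing one core have been tested in an assay on CHO cells for displacement of a labelled ligand from adenosine receptor A3 (Homo sapiens), read by scintillation counting, with a stated time of 120 min, tested at 10 uM; on this read-out lower numbers stand for less inhibition and higher numbers for more inhibition at the one concentration tested (going by the name of the read-out). Compound 1 `Nc1scc(CN2CCN(c3cccc4ccccc34)CC2)c1C(=O)c1ccc(Cl)cc1` gives 0%. Compound 2 `Nc1scc(CN2CCN(c3cc(F)ccc3F)CC2)c1C(=O)c1ccc(Cl)cc1` gives 2%. Compound 3 `Nc1scc(CN2CCN(c3ccc(F)c(Cl)c3)CC2)c1C(=O)c1ccc(Cl)cc1` gives 0%. Compound 3 stands level with compound 1 at the digits shown, the two together the lowest of the three numbers; its nearest neighbour is compound 1, with no change at the digits printed from compound 1 to compound 3 (within the scatter), and its furthest is compound 2, with a number 2 percentage points lower from compound 2 to compound 3 (within the scatter). Every step measured so far, including a number 2 percentage points higher from compound 1 to compound 2 (within the scatter), lies within the scatter, so none of the three aryl groups on the ring nitrogen has made a detectable difference in this assay.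

Among the compounds with values here, compound 4 `Nc1scc(CN2CCN(c3ccccc3Cl)CC2)c1C(=O)c1ccc(Cl)cc1` has not yet been measured. 2-chlorophenyl in place of 3-chloro-4-fluorophenyl on an amine nitrogen in a ring The steps that bear on this change are the two earlier swaps of the aryl group on that nitrogen, no change at the digits printed from compound 1 to compound 3 (within the scatter) and a number 2 percentage points lower from compound 2 to compound 3 (within the scatter), both within the scatter. A step of a number 1 percentage points higher from compound 3 to compound 4 (within the scatter) is therefore expected, nothing beyond the scatter. Compound 4 is estimated at 1%, between -8% and 10%.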

Compound 4, a percentage reported as inhibition, at one concentration (the size of the read-out at that concentration, not a potency): 0%
Estimate against measurement, compound 4: 1 percentage points above; the measured number falls inside the stated range.
By their numbers in this assay, from the lowest: compounds 1, 3, 4 and 2 (each within the scatter of the next).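

The 2-chlorophenyl group reads like the three aryl groups before it, with no change at the digits printed from compound 3 to compound 4 (within the scatter) and no change at the digits printed from compound 1 to compound 4 (within the scatter) and also a number 2 percentage points lower from compound 2 to compound 4 (within the scatter) in this assay at this place on the ring nitrogen. The earlier compounds shown here all carried either a fused second ring or at least one fluorine, so this result extends the flat picture to a phenyl ring bearing chlorine alone. Four different aryl groups now sit within the scatter of one another, and nothing available explains why they read alike.

Still open, going by these compounds, is whether any group here can raise the number clearly, such as an amine or a carboxylic acid on the phenyl ring, or a longer chain in place of the aryl group. Changes elsewhere on the shared core, such as replacing the chlorine of the 4-chlorobenzoyl part, also remain untested in these compounds.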